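Cytotoxicity notes: aryl substituent swaps on a shared core

The source may report more compounds than this note shows. Statements on the series, on what has been measured and on what is new or still open speak of the compounds shown alone.

Of the compounds shown here, three have been measured for cytotoxicity. Compound 1 `Cc1ccc(-c2ccc(C)n2-c2ccc(-c3nc4ccccc4s3)cc2)cc1` gives 30600 nM in an ADME assay on MCF-10A cells (Homo sapiens) for cytotoxicity, read by MTT assay, with a stated time of 72 h; a lower number here means a stronger inhibitor, a higher number a weaker inhibitor. Compound 2 `Cc1ccc(-c2ccc(F)cc2)n1-c1ccc(-c2nc3ccccc3s2)cc1` gives 40000 nM in this assay, and compound 3 `COc1ccc(-c2ccc(C)n2-c2ccc(-c3nc4ccccc4s3)cc2)cc1` gives 36300 nM. All three numbers sit close together: the change from compound 1 to compound 2 reads a 1.3-fold higher number from compound 1 to compound 2 (0.12 log units; within the scatter), from compound 1 to compound 3 a 1.2-fold higher number from compound 1 to compound 3 (0.07 log units; within the scatter), and from compound 2 to compound 3 a 1.1-fold lower number from compound 2 to compound 3 (0.04 log units; within the scatter). Compound 3 thus stands second highest of the three, with every neighbour within the scatter.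

Compound 4 `Cc1ccc(-c2ccc([N+](=O)[O-])cc2)n1-c1ccc(-c2nc3ccccc3s2)cc1` has not yet been measured. The change from compound 3 is nitro in place of methoxy on an aromatic carbon. Going by the values given here, the steps that bear on it are the earlier substituent swaps at the same place, all within the scatter, so no step beyond the scatter is expected in this assay. Compound 4 is estimated at 36000 nM, between 18000 nM and 72000 nM, which means an expected step of a 1.0-fold lower number from compound 3 to compound 4 (0.00 log units; within the scatter).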

Compound 4, half-maximal inhibitory concentration: 38800 nM
Beside the measured number, compound 4's estimate is 1.1-fold (0.03 log units) below it; low and high end bracket the measured number.
By their numbers in this assay, from the lowest: compounds 1, 3, 4 and 2 (each within the scatter of the next).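

Nitro brings a double bond outside aromatic rings and more hydrogen-bond acceptors than methoxy, yet at this place, on an aromatic carbon para to a large group, this assay reads a 1.1-fold higher number from compound 3 to compound 4 (0.03 log units; within the scatter). Measured against the other two groups, the nitro compound gives a 1.0-fold lower number from compound 2 to compound 4 (0.01 log units; within the scatter) and a 1.3-fold higher number from compound 1 to compound 4 (0.10 log units; within the scatter), so all four listed substituents, methyl, fluoro, methoxy and nitro, now stand within the scatter of one another, with no compound going against this. No accompanying measurement speaks to what lies behind this flat picture.

On these data alone, it remains open whether an amine, a carboxylic acid or a longer chain at this place would give a step beyond the scatter in this assay. The compounds shown also leave open whether the same flatness holds for changes elsewhere on the shared core.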